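From 3-bromophenyl to 2,4-dimethylphenyl on the amide nitrogen

A few compounds are considered here, and "the series" means these few. Any claim that something is new, unique, unknown or untested is made for them only; others in the source may bear on it.

Among the compounds with values here, in a functional assay on HT-29 cells (Homo sapiens) for cytotoxicity, read by MTT assay, with a stated time of 72 h (on this read-out lower numbers stand for stronger inhibition and higher numbers for weaker inhibition), compound 2 (`O=C(CN1CCN(c2nnc(Cc3ccccc3)c3ccccc23)CC1)Nc1cccc(Br)c1`) gives 13400 nM and holds the lower of the two numbers so far, while compound 1 (`Cc1ccc(F)cc1NC(=O)CN1CCN(c2nnc(Cc3ccccc3)c3ccccc23)CC1`) gives 171000 nM as the higher one. Compound 3 (`Cc1ccc(NC(=O)CN2CCN(c3nnc(Cc4ccccc4)c4ccccc34)CC2)c(C)c1`) has 2,4-dimethylphenyl in place of 3-bromophenyl on an amide-type nitrogen. Within the data shown here, only one measured step bears on this: a 13-fold lower number from compound 1 to compound 2 (1.11 log units; beyond the scatter) is a large change on the same nitrogen, where 3-bromophenyl replaced 5-fluoro-2-methylphenyl. In this assay the expected move is a 3.7-fold higher number from compound 2 to compound 3 (0.57 log units; beyond the scatter) toward a higher number, undoing part of that large step. Compound 3 is estimated at 50000 nM within a range of 15000 nM to 170000 nM for now.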

Compound 3, half-maximal inhibitory concentration: "not active" (no number reported)
No number was reported for compound 3; the estimate stays without a comparison.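

Compound 3 is reported as "not active" with no number, so no step from compound 2 to compound 3 can be read, and no data here explain this result. Where compound 3 stands numerically relative to compound 1 and compound 2 in this assay stays open.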